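The source may hold more compounds than are shown below. What is called first, only, known or untested is meant among the compounds shown, and "the series" means these compounds.

Compound 1 `C=C1CCC[C@H]2[C@](C)(CC3=C(O)C(=O)C=C(OC)C3=O)[C@@H](C)CC[C@]12C` is the stronger growth inhibitor of the two measured compounds in a functional assay on CHO-K1 cells (Cricetulus griseus) for cytotoxicity, read by sulforhodamine B assay, with a stated time of 48 h (a higher number here means a weaker inhibitor of growth, a lower number a stronger inhibitor of growth), where compound 1 gives 2000 nM. Compound 2 `C=C1CCC[C@H]2[C@](C)(Cc3c(O)c(O)cc4ncoc34)[C@@H](C)CC[C@]12C` gives 11000 nM in this assay, a gap beyond the scatter. Compound 3 `C=C1CCC[C@H]2[C@](C)(CC3=C(O)C(=O)C=C(NCC(=O)O)C3=O)[C@@H](C)CC[C@]12C` differs from compound 1 by (carboxymethyl)amino in place of methoxy on a double-bonded ring carbon. Going by the values given here, no measured pair shows this change, so its effect is not known; a step of modest size is expected, tending toward weaker growth inhibition. Compound 3 is estimated at 3500 nM, with a likely range from 1200 nM to 10000 nM. The expected step of a 1.8-fold higher number from compound 1 to compound 3 (0.24 log units; within the scatter) is a modest one.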

Compound 3, concentration for 50% growth inhibition: 3000 nM
Compound 3: middle estimate off by 1.2-fold (0.07 log units), on the high side; the range from low to high includes it.
By their numbers in this assay, from the lowest: compounds 1 and 3 (each within the scatter of the next); then compound 2.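

In this assay, (carboxymethyl)amino in place of methoxy on this double-bonded ring carbon gives a 1.5-fold higher number from compound 1 to compound 3 (0.18 log units; within the scatter). The position thus accepts a group of 5 heavy atoms in place of one of 2, with no difference that stands out from the scatter. Nothing measured bears on why this is so. Going by these compounds, it remains open whether the carboxylic acid of the new group matters at all, or only the nitrogen that joins it to the ring. A plain amine, an ester or a longer chain at this ring carbon would separate these, and none stands among the compounds shown.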